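This account rests on a few compounds, and the source may have more. Where it says the series, first, only, none or still open, it means among the compounds named here.

Measured in a functional assay on the whole organism (strain Wistar) for inhibition, with Rattus norvegicus as the target, read by paw edema, at a dose of 100 mg/kg by the oral route; on this read-out higher numbers stand for more inhibition at the one dose given (going by the name of the read-out) and lower numbers for less inhibition:
compound 1, `COc1cc2c(cc1OC)C(CC(=O)Nc1cccc(Cl)c1)CC2`, gives 37.5%
compound 2, `COc1cc2c(cc1OC)C(CC(=O)Nc1ccc(Cl)cc1)CC2`, gives 28.6%

Of the compounds shown here, two have been measured so far, and they share one core that carries an amide-type nitrogen bearing a chlorophenyl group. In this assay, among the compounds with values here, compound 2 gives 28.6%, the lower of the two numbers; the single step between them, a number 8.9 percentage points lower from compound 1 to compound 2 (within the scatter), lies within the scatter, so the two compounds stand together and no order between them can be claimed. This step concerns 4-chlorophenyl in place of 3-chlorophenyl on the amide-type nitrogen.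

Compound 3, `COc1cc2c(cc1OC)C(CC(=O)Nc1ccc([N+](=O)[O-])cc1)CC2`, has not been measured. It differs from compound 2 by nitro in place of chloro on an aromatic carbon. Within the data shown here, no measured step concerns this exchange of one group for another on the aromatic ring; the only step known, a number 8.9 percentage points lower from compound 1 to compound 2 (within the scatter), moved the same chlorine to another aromatic carbon and stayed within the scatter. With nothing to point in either direction, compound 3 is expected to stand near compound 2, with a step of a number 1.4 percentage points higher from compound 2 to compound 3 (within the scatter) that does not go beyond the scatter. Compound 3 is therefore estimated at 30% in this assay, within a range from 14% to 46%.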

Compound 3, a percentage reported as inhibition, in the whole organism at one dose (the size of the read-out at that dose, not a potency): 27.2%
The estimate for compound 3 lay 2.8 percentage points above the measured number; the measured number falls inside the stated range.
By their numbers in this assay, from the lowest: compounds 3, 2 and 1 (each within the scatter of the next, the first and the last beyond it).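

In this assay, the step at this place, para to a large group, is a number 1.4 percentage points lower from compound 2 to compound 3 (within the scatter), and it lies within the scatter even though nitro brings more heavy atoms and more hydrogen-bond acceptors than chloro. The earlier pair showed only that moving the chlorine to another aromatic carbon left the two compounds together; this pair shows that replacing the chlorine with a different group at this one place also allows no order to be claimed, so compound 2 and compound 3 stand together. No information is available to explain this result.

The compounds shown leave open whether an amine, a carboxylic acid or a methoxy group at this place would stand apart from chloro and nitro, or whether the ring without any such group would do so. They also leave open how nitro would behave at the position the chlorine holds in compound 1, since the only change shown at that position is the move of the chlorine itself.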